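This account rests on a few compounds, and the source may have more. Where it says the series, first, only, none or still open, it means among the compounds named here.

Three compounds share one core and were tested in an ADME assay on MT2 cells (Homo sapiens) for cytotoxicity, read by MTT assay; on this read-out lower numbers stand for higher toxicity in this test and higher numbers for lower toxicity in this test. Compound 1 `Fc1cccc(F)c1Cc1cnc(Nc2ccc(Oc3cccnc3)c(Cl)c2)o1` gives 16000 nM, compound 2 `Fc1cccc(F)c1Cc1cnc(Nc2ccc(Oc3cccnc3)cc2)o1` gives 22000 nM, and compound 3 `OCc1ccc(Nc2ncc(Cc3c(F)cccc3F)o2)cc1Cl` gives 90000 nM. Compound 1 and compound 2 differ by hydrogen in place of chloro on an aromatic carbon, and that change made a 1.4-fold higher number from compound 1 to compound 2 (0.14 log units; within the scatter). Compound 3 differs from compound 1 by hydroxymethyl in place of (pyridin-3-yl)oxy on an aromatic carbon, and this change gave a 5.6-fold higher number from compound 1 to compound 3 (0.75 log units; beyond the scatter).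

Compound 4 `OCc1ccc(Nc2ncc(Cc3c(F)cccc3F)o2)cc1` is not yet measured. It differs from compound 3 by hydrogen in place of chloro on an aromatic carbon. This is the same kind of change as from compound 1 to compound 2, but the place is not identical: in compound 3 the leaving group sits ortho to a hydroxymethyl group, whereas in compound 1 it sits ortho to a (pyridin-3-yl)oxy group. Because compound 1 to compound 2 gave a 1.4-fold higher number from compound 1 to compound 2 (0.14 log units; within the scatter), a similarly small step of a 1.2-fold higher number from compound 3 to compound 4 (0.09 log units; within the scatter) is expected from compound 3 to compound 4. Compound 4 is therefore estimated at 110000 nM, with a likely range from 45000 nM to 260000 nM.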

Compound 4, half-maximal cytotoxic concentration: > 100000 nM
Compound 4: no number, only a limit; the forecaster's own chance of this, stated with the estimate: 30%; the middle value lies beyond the limit too.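

In this assay compound 4 gives > 100000 nM, which is a limit of the assay and not a number. Hydrogen in place of chloro gives an at least 1.1-fold higher number from compound 3 to compound 4 (0.04 log units; that floor lies within the scatter), so this step has only a floor, and its true size on this core stays unknown: the same change on two cores in this assay, a 1.4-fold higher number (0.14 log units; within the scatter) from compound 1 to compound 2 and an at least 1.1-fold higher number (0.04 log units; that floor lies within the scatter) from compound 3 to compound 4; the limit leaves it open whether they differ. Hydroxymethyl in place of (pyridin-3-yl)oxy gives an at least 4.5-fold higher number from compound 2 to compound 4 (0.65 log units; beyond the scatter), so this change raises the number on both cores, though how closely the sizes match cannot be told: the same change on two cores in this assay, a 5.6-fold higher number (0.75 log units; beyond the scatter) from compound 1 to compound 3 and an at least 4.5-fold higher number (0.65 log units; beyond the scatter) from compound 2 to compound 4; the limit leaves it open whether they differ.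

The compounds shown leave open how other groups in place of hydroxymethyl, such as an amine or a carboxylic acid, would read in this test. They also leave open how far either change carries to cores beyond these two.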